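This account rests on a few compounds, and the source may have more. Where it says the series, first, only, none or still open, it means among the compounds named here.

Measured so far, in an ADME assay on Caco-2 cells (Homo sapiens) for permeability, in the apical to basolateral direction; on this read-out higher numbers stand for higher permeability and lower numbers for lower permeability:

Compound 1 `Cn1nc2c(=O)n(CC3(O)CCN(Cc4ccc(-c5ccco5)cc4Cl)CC3)cnc2c1-c1ccc(C2(N)CC2)cc1` gives 1.99 10^-6 cm/s in this assay.
Compound 2 `Cn1nc2c(=O)n(CC3(O)CCN(Cc4ccc(-c5ccco5)cc4Cl)CC3)cnc2c1-c1ccc(CNC=O)cc1` gives 0.65 10^-6 cm/s.
Compound 3 `CNCc1ccc(-c2c3ncn(CC4(O)CCN(Cc5ccc(-c6ccco6)cc5Cl)CC4)c(=O)c3nn2C)cc1` gives 1.06 10^-6 cm/s.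

Compound 1 stands highest of the three numbers. Its nearest neighbour is compound 3, reached by a step of a 1.9-fold lower number from compound 1 to compound 3 (0.27 log units; within the scatter), which is within the scatter; the step of a 3.1-fold lower number from compound 1 to compound 2 (0.49 log units; beyond the scatter) is the only one beyond it. Between the two lower compounds, a 1.6-fold higher number from compound 2 to compound 3 (0.21 log units; within the scatter) is again within the scatter.

Compound 4 `Cn1nc2c(=O)n(CC3(O)CCN(Cc4ccc(-c5ccco5)cc4Cl)CC3)cnc2c1-c1ccc(CN)cc1` differs from compound 1 at a single place: aminomethyl in place of 1-aminocyclopropyl on an aromatic carbon.

Going by the values given here, two measured steps bear on this change. The closest is the move from compound 1 to compound 3, where (methylamino)methyl took the place of 1-aminocyclopropyl and gave a 1.9-fold lower number from compound 1 to compound 3 (0.27 log units; within the scatter), a shift within the scatter. The move to compound 2, where (formylamino)methyl entered, gave a 3.1-fold lower number from compound 1 to compound 2 (0.49 log units; beyond the scatter), beyond the scatter. Aminomethyl is nearer in kind to (methylamino)methyl than to (formylamino)methyl, so a small downward step, within the scatter, is expected. Compound 4 is therefore estimated at 1.3 10^-6 cm/s, in the range 0.6 10^-6 cm/s to 2.8 10^-6 cm/s, which means an expected step of a 1.5-fold lower number from compound 1 to compound 4 (0.18 log units; within the scatter).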

Compound 4, apparent permeability: 0.92 10^-6 cm/s
Compound 4: middle estimate off by 1.4-fold (0.15 log units), on the high side; the range from low to high includes it.
By their numbers in this assay, from the lowest: compounds 2, 4, 3 and 1 (each within the scatter of the next, the first and the last beyond it).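

In this assay, aminomethyl in place of 1-aminocyclopropyl gives a step beyond the scatter (a 2.2-fold lower number from compound 1 to compound 4 (0.34 log units; beyond the scatter)), so at this position the ring-bearing group can be told apart from the plain aminomethyl group, although compound 3, with its (methylamino)methyl group, stays within the scatter of compound 1. On the amine nitrogen, hydrogen cannot be told apart from methyl (a 1.2-fold lower number from compound 3 to compound 4 (0.06 log units; within the scatter)) or from formyl (a 1.4-fold higher number from compound 2 to compound 4 (0.15 log units; within the scatter)), so compounds 2, 3 and 4 form one group within the scatter. No measured evidence here accounts for these steps. On these data alone, it remains open whether an open-chain 2-aminopropan-2-yl group or a 1-aminocyclobutyl group would stand with compound 1 or with compound 4. As far as these compounds go, how a hydroxymethyl group, which has no amine nitrogen, would compare at this position is also open.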